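Replacing a 4-cyanophenyl group on a weak inhibitor

A few compounds are considered here, and "the series" means these few. Any claim that something is new, unique, unknown or untested is made for them only; others in the source may bear on it.

In a functional assay on FaDu cells (Homo sapiens) for inhibition, read by sulforhodamine B assay (on this read-out lower numbers stand for stronger inhibition and higher numbers for weaker inhibition), compound 1 `COC(=O)CC/C(C)=C/Cc1c(OC)c(C)c2c(c1OCC#CCN1CCN(c3ccc(C#N)cc3)CC1)C(=O)OC2` gives > 50000 nM as a limit of the assay and not a number. In this assay, among the measured compounds shown here, compound 2 `CCCCNc1ccc(CC#CCOc2c(C/C=C(\C)CCC(=O)OC)c(OC)c(C)c3c2C(=O)OC3)cc1` gives 21200 nM as a true number, although no single structural step links it to compound 1.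

Compound 3 `COC(=O)CC/C(C)=C/Cc1c(OC)c(C)c2c(c1OCC#CCN1CCN(C(=O)C3COc4ccccc4O3)CC1)C(=O)OC2` differs from compound 1 by (2,3-dihydro-1,4-benzodioxin-2-yl)carbonyl in place of 4-cyanophenyl on an amine nitrogen in a ring and so carries (2,3-dihydro-1,4-benzodioxin-2-yl)carbonyl in place of 4-cyanophenyl on an amine nitrogen in a ring. For the measured compounds named here, no measured step shows what this swap does, so the estimated step of an at least 1.4-fold lower number from compound 1 to compound 3 (0.15 log units; that floor lies within the scatter) is expected to be modest and, if it appears at all, towards stronger inhibition. Going by the values given here, this expectation leans on compound 2 at 21200 nM as the one measured number, which still stands for weak inhibition. For compound 3 the estimated value is 35000 nM with 12000 nM to 70000 nM as its expected range.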

Compound 3, half-maximal inhibitory concentration: > 50000 nM
Compound 3: only a limit was reported; the forecaster's own chance of this, stated with the estimate: 45%; middle value at least 1.4-fold (0.15 log units) from the limit.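

Among the compounds shown here, compound 1 and compound 3 both stop at the same assay limit, so no step between them can be read, because neither has a true number: the limit of > 50000 nM in this assay, at which 2 of the 3 values shown sit. From the compounds shown here alone, whether putting (2,3-dihydro-1,4-benzodioxin-2-yl)carbonyl in place of 4-cyanophenyl changes inhibition at all stays open.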